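Dithiocarbamate benzamides: trimming the piperazine substituent

This account rests on a few compounds, and the source may have more. Where it says the series, first, only, none or still open, it means among the compounds named here.

Measured so far:
- compound 1, `Nc1ccccc1NC(=O)c1ccc(CSC(=S)N2CCN(C(c3ccccc3)c3ccccc3)CC2)cc1`: 9.9%
- compound 2, `CN(Cc1cccnc1)C(=S)SCc1ccc(C(=O)Nc2ccccc2N)cc1`: 85.5%

In a functional assay on MGC-803 cells (Homo sapiens) for antiproliferative activity, read by CCK-8 assay, with a stated time of 72 h, tested at 8 uM (on this read-out higher numbers stand for a stronger effect at the one concentration tested and lower numbers for a weaker effect), compound 1 gives 9.9%, the lowest of the two numbers recorded. Among the measured compounds shown here, compound 2 gives 85.5% in this assay, a number that lies beyond the usual scatter above that of compound 1; with only these two points, and no single-change step between them, nothing more than this gap can be read from the pair.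

The next compound, compound 3 `Nc1ccccc1NC(=O)c1ccc(CSC(=S)N2CCN(Cc3ccccc3)CC2)cc1`, keeps the whole of compound 1 except at one place: hydrogen in place of phenyl on a saturated chain carbon bound to an amine nitrogen in a ring and an aromatic carbon. The amine-bearing portion of compound 3 thus becomes smaller than that of compound 1, while the rest of the molecule is unchanged.

For the measured compounds named here, no measured step of this kind exists in the set, so the size of the change is open. Given that the only strong number comes from compound 2 with 85.5%, an upward step is expected for compound 3, a number 25.1 percentage points higher from compound 1 to compound 3 (beyond the scatter), but with wide uncertainty. The estimate for compound 3 in this assay is 35%, with an expected range from 8% to 70%.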

Compound 3, a percentage reported as inhibition, at one concentration (the size of the read-out at that concentration, not a potency): 19.7%
Estimate against measurement, compound 3: 15.3 percentage points above; measured number inside the range.
By their numbers in this assay, from the lowest: compounds 1 and 3 (each within the scatter of the next); then compound 2.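

In this assay, hydrogen in place of phenyl on a saturated chain carbon bound to an amine nitrogen in a ring and an aromatic carbon gives a number 9.8 percentage points higher from compound 1 to compound 3 (within the scatter). This single-change step shows that one of the two phenyl groups on that carbon can be replaced by hydrogen without a change that stands out from the scatter, so this trim alone does not separate the two compounds on this read-out. No measurement here offers an explanation for this outcome.

Open, going by these compounds, is what a methyl or a hydroxyethyl group would give in this assay on the same ring amine nitrogen, in place of the chain carbon and its remaining phenyl, and whether an amine or a carboxylic acid on that phenyl would move the number beyond the scatter. Also open, on these data alone, is how the compounds would compare across a range of concentrations, since a read-out at one concentration gives the size of the effect there and not a potency.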